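Swapping the aryl group on the hydrazone of compound 2

The source may report more compounds than this note shows. Statements on the series, on what has been measured and on what is new or still open speak of the compounds shown alone.

Two compounds share one core and differ only in the aromatic ring attached to the carbon that is double-bonded to nitrogen. Compound 1 `CN(C)CCn1cnnc1-c1cc(Oc2ccc(NC(=O)N/N=C/c3ccc(O)c(Br)c3)cc2F)ccn1` carries a 3-bromo-4-hydroxyphenyl ring there, and in a functional assay on A549 cells (Homo sapiens) for cytotoxicity, read by MTT assay, with a stated time of 72 h (on this read-out lower numbers stand for stronger inhibition and higher numbers for weaker inhibition), compound 1 gives 1370 nM. Compound 2 `CN(C)CCn1cnnc1-c1cc(Oc2ccc(NC(=O)N/N=C/c3ccc(F)cc3F)cc2F)ccn1` carries a 2,4-difluorophenyl ring instead, and in this assay compound 2 gives 1870 nM. Going by the values given here, the step of a 1.4-fold higher number from compound 1 to compound 2 (0.14 log units; within the scatter) is the only measured step so far, and it lies within the scatter, so the two numbers cannot be told apart. Compound 2 therefore holds the higher of the two numbers shown, with compound 1 close beside it.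

Compound 3 `CN(C)CCn1cnnc1-c1cc(Oc2ccc(NC(=O)N/N=C/c3ccc(O)c(O)c3)cc2F)ccn1` is built by the change (3,4-dihydroxyphenyl in place of 2,4-difluorophenyl on a carbon with a double bond to nitrogen). Among the compounds with values here, the only step that bears on it is the one from compound 1 to compound 2, which was small; a ring with a hydroxyl group came with a number of the same size as the fluorinated ring. The expectation is therefore a step of a 1.3-fold lower number from compound 2 to compound 3 (0.13 log units; within the scatter), that is, none beyond the scatter. For compound 3 in this assay the estimate is 1400 nM, within a range from 600 nM to 3500 nM.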

Compound 3, half-maximal inhibitory concentration: > 100000 nM
Compound 3 ended at the assay's limit; the forecaster's own chance of this, stated with the estimate: 5%; middle value at least 71-fold (1.85 log units) away from the limit.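

In this assay compound 3 stands at a limit of the assay, not at a measured number: the limit of > 100000 nM in this assay, at which 1 of the 3 values shown sits.

With only compound 1 and compound 2 in hand, the aryl group on the carbon with a double bond to nitrogen seemed open to exchange, but compound 3 shows that this place can matter a great deal: 3,4-dihydroxyphenyl in place of 2,4-difluorophenyl gives an at least 53-fold higher number from compound 2 to compound 3 (1.72 log units; beyond the scatter), and hydroxy in place of bromo on an aromatic carbon gives an at least 72-fold higher number from compound 1 to compound 3 (1.86 log units; beyond the scatter). A hydroxy group on this ring is not enough on its own to produce such a step, since compound 1 also carries one and lies within the scatter of compound 2; among the three compounds, the large step appears only with 3,4-dihydroxyphenyl.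

The compounds shown do not tell whether the large step depends on having both hydroxy groups, a question that a ring with a methoxy group or an amine in place of one of them could address. They also give no cause for the step, so the reason for it remains open.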